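This account rests on a few compounds, and the source may have more. Where it says the series, first, only, none or still open, it means among the compounds named here.

Compound 1 `O=C1c2ccc(OCc3cccc(-c4ccccc4)c3)cc2CN1C1CCCC1` was tested in an assay on HEK293 cells for positive allosteric modulation of metabotropic glutamate receptor 2 (Rattus norvegicus), read by thallium flux; a lower number here means that less compound is needed, a higher number that more compound is needed for the effect. Compound 1 gave > 5000 nM, which is a limit of the assay rather than a number. Among the values shown, compound 1 sits at the limit of > 5000 nM in this assay, at which 1 of the 2 values shown sits, so only a boundary is known for it. Compound 2 `O=C(O)c1cc(-c2cccc(COc3ccc4c(=O)n(C5CCCC5)sc4c3)c2)cc([N+](=O)[O-])c1` differs from compound 1 in more than one place and carries a carboxy group. In this assay compound 2 gives 200 nM. Together these two values show that compound 2 reaches a measurable effect where compound 1 does not.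

Compound 3 `O=C(O)c1ccc(-c2cccc(COc3ccc4c(c3)CN(C3CCCC3)C4=O)c2)c(Cl)c1` keeps the core of compound 1 and changes one group: 4-carboxy-2-chlorophenyl in place of phenyl on an aromatic carbon. Going by the values given here, no measured pair of compounds differs in exactly this way, so the size of the step has to be judged from what is available. Compound 2, also carrying a carboxy group, gives 200 nM. On that basis a gain larger than the usual scatter is expected, and the step from compound 1 to compound 3 is estimated at an at least 8.3-fold lower number from compound 1 to compound 3 (0.92 log units; beyond the scatter). Compound 3 is therefore expected to give about 600 nM, most likely between 150 nM and 3000 nM.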

Compound 3, half-maximal effective concentration: 110 nM
The estimate for compound 3 lay 5.5-fold (0.74 log units) above the measured number; the whole stated range lies above it.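

Until now, no two compounds shown differed in only one place, so nothing could be credited to a single change. Here, with the shared core held constant, replacing phenyl with 4-carboxy-2-chlorophenyl on an aromatic carbon, meta to a large group, gives in this assay an at least 45-fold lower number from compound 1 to compound 3 (1.65 log units; beyond the scatter), so this position accepts the larger group and the change moves the result by far more than the usual scatter. This step gives only a minimum and its full size stays unknown, because compound 1 stands at a limit of the assay rather than at a number: the limit of > 5000 nM in this assay, at which 1 of the 3 values shown sits.

The carboxylic acid and the chlorine enter together, so these compounds cannot show which of the two carries the gain or whether both are needed. Going by these compounds, a 4-carboxyphenyl group without the chlorine, a 2-chlorophenyl group without the acid, and a tetrazole or a primary amide in place of the acid would each separate these contributions, and how any of them would behave remains open.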